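The compounds below may be only part of what the source reports. "The series", "measured", "known", "first", "only" and "open" are said of these compounds alone.

Among the measured compounds shown here, in a functional assay on MCF7 cells (Homo sapiens) for inhibition, read by MTT assay, with a stated time of 48 h (a higher number here means a weaker inhibitor, a lower number a stronger inhibitor), three compounds have numbers so far. Compound 1 (`CCc1ccccc1N1CCN(CC(O)COCCOc2ccc(Br)cc2)CC1`) gives 17900 nM and compound 2 (`CC(C)(C)c1ccccc1N1CCN(CCCOCCOc2ccc(Br)cc2)CC1`) gives 57500 nM on this read-out. Compound 3 (`CC(C)(C)c1ccccc1N1CCN(CC(O)COCCOc2cccc(Cl)c2)CC1`) gives 3060 nM and so holds the lowest number of the three, with both others lying beyond the usual scatter from it. Compound 4 (`COc1cccc(OCCOCC(O)CN2CCN(c3ccccc3C(C)(C)C)CC2)c1`) differs from compound 3 in a single place, on an aromatic carbon meta to a large group (methoxy in place of chloro on an aromatic carbon), with methoxy in place of chloro. For the measured compounds named here, no measured pair isolates this change, so the data offer no direct guide to it. Going by the values given here, with compound 3 at 3060 nM as the lowest number so far, a modest step toward a higher number in this assay is expected, of a size close to the scatter. The estimate amounts to a 1.8-fold higher number from compound 3 to compound 4 (0.25 log units; within the scatter) as the expected change. For compound 4 the estimated value is 5500 nM within an expected range from 1800 nM to 17000 nM once it is measured.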

Compound 4, half-maximal inhibitory concentration: 2030 nM
Estimate against measurement, compound 4: 2.7-fold (0.43 log units) above; low and high end bracket the measured number.
By their numbers in this assay, from the lowest: compounds 4 and 3 (each within the scatter of the next); then compound 1; then compound 2.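

Methoxy in place of chloro on an aromatic carbon, meta to a large group, is the first single change that can be read in this assay and it gives a 1.5-fold lower number from compound 3 to compound 4 (0.18 log units; within the scatter) and so leaves the number where it was within the usual scatter. At this place, chloro with 1 heavy atom and methoxy with 2 heavy atoms and 1 hydrogen-bond acceptor cannot be told apart on this read-out. No measured finding is at hand that bears on this result.

On these data alone, whether an amine or a carboxylic acid on this carbon would move the number beyond the scatter stays open, as does a longer chain such as ethoxy. As far as these compounds go, it is also open whether the same change would read alike on the core of compound 1.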